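The source may hold more compounds than are shown below. What is called first, only, known or untested is meant among the compounds shown, and "the series" means these compounds.

Working notes on the series, read in an ADME assay on the whole organism (strain CD1) for pharmacokinetics, with Mus musculus as the target, read by LC-MS, at a dose of 5 mg/kg by the intravenous route; on this read-out higher numbers stand for fast clearance and lower numbers for slow clearance. Compound 1 `Cc1c(Oc2cnc(C(=O)NC(C)CO)cn2)ccc2c1B(O)OC2` gives 2.13 mL/min/kg, compound 2 `CCC[C@H](CO)NC(=O)c1cnc(Oc2ccc3c(c2C)B(O)OC3)cn1` gives 4.05 mL/min/kg, and compound 3 `Cc1c(Oc2cnc(C(=O)N[C@@H](CO)CC(F)(F)F)cn2)ccc2c1B(O)OC2` gives 3.97 mL/min/kg. Compound 3 holds no distinct place among these numbers, as all three lie within the scatter of one another: a 1.0-fold lower number from compound 2 to compound 3 (0.01 log units; within the scatter), and a 1.9-fold higher number from compound 1 to compound 3 (0.27 log units; within the scatter).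

The next step leads to compound 4 `Cc1c(Oc2cnc(C(=O)N3CC(C)(O)C3)cn2)ccc2c1B(O)OC2`. The change is 3-hydroxy-3-methylazetidin-1-yl in place of (3,3,3-trifluoro-1-(hydroxymethyl)propyl)amino on a carbonyl carbon.

The measured steps bear on this only indirectly. Going by the values given here, each exchanges one open chain on an amide-type nitrogen for another, and no measured compound carries a ring at this place, so the change itself is untested. Given a 1.9-fold higher number from compound 1 to compound 2 (0.28 log units; within the scatter), and a 1.9-fold higher number from compound 1 to compound 3 (0.27 log units; within the scatter), no shift beyond the scatter is expected in either direction. The estimated step is a 1.3-fold lower number from compound 3 to compound 4 (0.12 log units; within the scatter), which is expected to remain within the scatter. Compound 4 is expected at 3 mL/min/kg. The estimated range for compound 4 runs from 1.3 mL/min/kg to 7 mL/min/kg.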

Compound 4, clearance: 4.07 mL/min/kg
The estimate for compound 4 lay 1.4-fold (0.13 log units) below the measured number; the measured number falls inside the stated range.
By their numbers in this assay, from the lowest: compounds 1, 3, 2 and 4 (each within the scatter of the next).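

In this assay, the first ring at this place on the carbonyl carbon stands within the scatter of all three open chains: a 1.0-fold higher number from compound 3 to compound 4 (0.01 log units; within the scatter), a 1.0-fold higher number from compound 2 to compound 4 (0.00 log units; within the scatter), and a 1.9-fold higher number from compound 1 to compound 4 (0.28 log units; within the scatter). The read-out therefore does not separate 3-hydroxy-3-methylazetidin-1-yl from the open-chain amino groups shown here, and the series at this position now spans both ring and open-chain groups on the shared core. The entering group has a four-membered non-aromatic ring and no defined stereocentre, yet neither feature goes with a number outside the scatter, and no information is available to explain this result.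

Every group shown at this place carries a hydroxyl, so it remains open whether the numbers would stay within the scatter with an unsubstituted azetidin-1-yl or with a chain ending in a carboxylic acid. Larger rings such as pyrrolidine or piperidine, and an amine in place of the hydroxyl on the azetidine ring, also remain open.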